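Homologation of the amino-ester chain in the sulfonate-bicyclic nucleoside series

This account rests on a few compounds, and the source may have more. Where it says the series, first, only, none or still open, it means among the compounds named here.

Of the compounds shown here, three have been measured in a functional assay on MT4 cells (Homo sapiens); on this read-out lower numbers stand for higher toxicity in this test and higher numbers for lower toxicity in this test. Compound 1 `COC(=O)C(=O)CNC1=CS(=O)(=O)O[C@@]12[C@@H](CO[Si](C)(C)C(C)(C)C)O[C@@H](n1cc(C)c(=O)n(C)c1=O)[C@@H]2O[Si](C)(C)C(C)(C)C` gives 10300 nM. Compound 2 `Cc1cn([C@@H]2O[C@H](CO[Si](C)(C)C(C)(C)C)[C@@]3(OS(=O)(=O)C=C3NC(N)=O)[C@H]2O[Si](C)(C)C(C)(C)C)c(=O)n(C)c1=O` gives 3700 nM. Compound 3 `COC(=O)CNC1=CS(=O)(=O)O[C@@]12[C@@H](CO[Si](C)(C)C(C)(C)C)O[C@@H](n1cc(C)c(=O)n(C)c1=O)[C@@H]2O[Si](C)(C)C(C)(C)C` gives 105000 nM, the highest of the three numbers; its nearest neighbour on this read-out is compound 1, its furthest compound 2.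

The measured steps leading into compound 3 are a 10-fold higher number from compound 1 to compound 3 (1.01 log units; beyond the scatter) and a 28-fold higher number from compound 2 to compound 3 (1.45 log units; beyond the scatter). Both are large, and both concern a change in the group on the amine nitrogen, or in a carbonyl carbon of that group, rather than the length of the saturated chain between the amine nitrogen and the ester.

Compound 4 `COC(=O)CCNC1=CS(=O)(=O)O[C@@]12[C@@H](CO[Si](C)(C)C(C)(C)C)O[C@@H](n1cc(C)c(=O)n(C)c1=O)[C@@H]2O[Si](C)(C)C(C)(C)C` differs from compound 3 as follows: (methoxycarbonyl)methyl in place of methoxycarbonyl on a saturated chain carbon bound to an amine nitrogen The chain carries one more carbon, and the ester itself is kept. Among the measured compounds shown here, no measured step shows the effect of lengthening this chain, so the steps from compound 1 and compound 2 to compound 3 bear on it only indirectly: they show that this part of the structure moves the read-out, not which way a homologation moves it.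

For compound 4 the step from compound 3 is therefore expected to stay within the scatter, a 1.2-fold lower number from compound 3 to compound 4 (0.07 log units; within the scatter), with the range widened to allow for the lack of a direct precedent. Compound 4 is estimated at 90000 nM, between 35000 nM and 230000 nM.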

Compound 4, half-maximal cytotoxic concentration: > 250000 nM
Compound 4: a limit, no number (the forecaster's own chance of this, stated with the estimate: 20%); middle value at least 2.7-fold (0.44 log units) away from the limit.
By their numbers in this assay, from the lowest: compound 2; then compound 1; then compound 3. At a limit, above all of these: compound 4.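

In this assay compound 4 gives > 250000 nM, which is a limit of the assay and not a number, and the series reaches that limit only here: the limit of > 250000 nM in this assay, at which 1 of the 4 values shown sits.

Going from (methoxycarbonyl)methyl to 2-(methoxycarbonyl)ethyl on the amine nitrogen, with the ester kept, gives the first direct reading of chain length at this position, and it is not neutral: an at least 2.3-fold higher number from compound 3 to compound 4 (0.37 log units; beyond the scatter), a step printed as beyond the scatter and pointing towards lower toxicity in this test. The two wider steps, an at least 24-fold higher number from compound 1 to compound 4 (1.38 log units; beyond the scatter) and an at least 67-fold higher number from compound 2 to compound 4 (1.82 log units; beyond the scatter), place compound 4 beyond all three earlier compounds, so the 2-(methoxycarbonyl)ethyl group stands at the low-toxicity end of the groups shown on this nitrogen.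

From the compounds shown here alone, the true size of all three steps stays open, as each has only a lower bound. Also open, going by these compounds, is whether a longer chain such as 3-(methoxycarbonyl)propyl, or a carboxylic acid in place of the methyl ester of 2-(methoxycarbonyl)ethyl, would keep the read-out at this limit or bring it back into the measurable range.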